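Aryl change on the carbon double-bonded to nitrogen

This account rests on a few compounds, and the source may have more. Where it says the series, first, only, none or still open, it means among the compounds named here.

Measured so far:
compound 1 `COc1ccc(/C=N\NC(=S)NC(C)(C)CCC[C@](C)(O)[C@@H]2CC=C(C)CC2)cc1` gives 5100 nM in a functional assay on NCI-H460 cells (Homo sapiens) for cytotoxicity, read by sulforhodamine B assay; on this read-out lower numbers stand for stronger inhibition of growth and higher numbers for weaker inhibition of growth
compound 2 `CC1=CC[C@@H]([C@@](C)(O)CCCC(C)(C)NC(=S)N/N=C\c2cccc([N+](=O)[O-])c2)CC1` gives 8290 nM in this assay

Among the compounds with values here, compound 2 stands as the higher of the two numbers, and the only measured step, a 1.6-fold higher number from compound 1 to compound 2 (0.21 log units; within the scatter), lies within the scatter. Compound 3 `CC1=CC[C@@H]([C@@](C)(O)CCCC(C)(C)NC(=S)N/N=C\c2ccccc2Cl)CC1` differs from compound 2 by 2-chlorophenyl in place of 3-nitrophenyl on a carbon with a double bond to nitrogen. Within the data shown here, the one step that bears on it is an aryl exchange at the same place and was within the scatter, so in this assay no step beyond the scatter is expected in either direction. Compound 3 is therefore estimated at 7000 nM, range 2500 nM to 20000 nM, an expected step of a 1.2-fold lower number from compound 2 to compound 3 (0.07 log units; within the scatter).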

Compound 3, concentration for 50% growth inhibition: 24600 nM
Compound 3: the middle estimate sits 3.5-fold (0.55 log units) below what was measured; measured number outside the range, above it.
By their numbers in this assay, from the lowest: compounds 1 and 2 (each within the scatter of the next); then compound 3.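

In this assay the carbon with a double bond to nitrogen is not indifferent to its aryl group: 2-chlorophenyl brings a 3.0-fold higher number from compound 2 to compound 3 (0.47 log units; beyond the scatter) and a 4.8-fold higher number from compound 1 to compound 3 (0.68 log units; beyond the scatter), whereas 3-nitrophenyl and 4-methoxyphenyl stay within the scatter of each other. Compound 3 thus stands apart from both earlier compounds, with weaker inhibition of growth. Nothing measured here accounts for this difference. Open, from the compounds shown here alone, is whether the step follows the chlorine itself or the place it holds on the ring. Also open, going by these compounds, is how a phenyl carrying an amine or a carboxylic acid would read at this carbon.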